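The compounds below may be only part of what the source reports. "The series", "measured", "known", "first", "only" and "open" are said of these compounds alone.

Compound 2 `OCc1cn(Cc2cccc(C(F)(F)F)c2)c2ccccc12` has 39 nM as its number in a functional assay on NCI-H460 cells (Homo sapiens) for cytotoxicity, read by sulforhodamine B assay, with a stated time of 3 days (on this read-out higher numbers stand for weaker inhibition and lower numbers for stronger inhibition), and compound 1 `OCc1cn(Cc2cccc(Br)c2)c2ccccc12` has 28 nM as its number. For the measured compounds named here, these are the only two numbers so far and they lie within the scatter of each other, so compound 2 stands level with compound 1. Compound 3 `O=[N+]([O-])c1cccc(Cn2cc(CO)c3ccccc32)c1` keeps the shared core and carries nitro in place of trifluoromethyl on an aromatic carbon. This exact swap has never been measured. Going by the values given here, the one measured step that bears on it is a different swap at the same place, trifluoromethyl in place of bromo on an aromatic carbon (a 1.4-fold higher number from compound 1 to compound 2 (0.14 log units; within the scatter)), and that step stays within the scatter. Among the compounds with values here, with only this small step as a guide, no change beyond the scatter is expected in this assay and the expected step is a 1.1-fold lower number from compound 2 to compound 3 (0.05 log units; within the scatter) at its middle. For compound 3 the estimated value is 35 nM with an expected range from 14 nM to 90 nM as its likely span.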

Compound 3, half-maximal inhibitory concentration: 39 nM
Beside the measured number, compound 3's estimate is 1.1-fold (0.05 log units) below it; low and high end bracket the measured number.
By their numbers in this assay, from the lowest: compounds 1, 2 and 3 (each within the scatter of the next).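

In this assay, this position on the aromatic ring now carries three different groups, and nitro adds a third reading to the two earlier ones. Nitro in place of trifluoromethyl gives no change at the digits printed from compound 2 to compound 3 (within the scatter), and nitro in place of bromo gives a 1.4-fold higher number from compound 1 to compound 3 (0.14 log units; within the scatter), so across compounds 1, 2 and 3 this assay does not separate the groups, even though nitro counts hydrogen-bond acceptors and the other two groups do not enter that comparison with any. Nothing measured here explains why the three read alike.

Going by these compounds, whether this holds for a group of another kind at the same place, such as an amine or a carboxylic acid, stays open. So does whether a longer chain there would also stay within the scatter.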